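Swapping the sulfonyl aryl group: a 4-methoxyphenyl variant

The source may hold more compounds than are shown below. What is called first, only, known or untested is meant among the compounds shown, and "the series" means these compounds.

Three close analogues built on the shared core of compound 1 `O=S(=O)(NCCCNc1nccc(-c2c(-c3cccc(F)c3)nc3sccn23)n1)c1cccc(F)c1` have been measured in a functional assay on A-375 cells (Homo sapiens) for cytotoxicity, read by MTT assay; a lower number here means a stronger inhibitor, a higher number a weaker inhibitor. Compound 1 gives 13700 nM in this assay. Compound 2 `O=S(=O)(NCCCNc1nccc(-c2c(-c3cccc(F)c3)nc3sccn23)n1)c1ccc(F)cc1` gives 14500 nM, and compound 3 `O=S(=O)(NCCNc1nccc(-c2c(-c3cccc(F)c3)nc3sccn23)n1)c1ccc(Br)cc1` gives 13500 nM. The three numbers lie close together: the step of a 1.1-fold higher number from compound 1 to compound 2 (0.02 log units; within the scatter) and the step of a 1.0-fold lower number from compound 1 to compound 3 (0.01 log units; within the scatter) are both within the scatter, so compound 1 sits among its neighbours without a separation that can be read.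

Compound 4 `COc1ccc(S(=O)(=O)NCCCNc2nccc(-c3c(-c4cccc(F)c4)nc4sccn34)n2)cc1` differs from compound 1 by one change: 4-methoxyphenyl in place of 3-fluorophenyl on a sulfonyl sulfur. The step that bears on it most directly is a 1.1-fold higher number from compound 1 to compound 2 (0.02 log units; within the scatter), which also alters the aryl group on the sulfonyl sulfur and moves the number by less than the scatter. No step beyond the scatter is therefore expected in this assay, in either direction, and compound 4 is estimated at 14000 nM, in the range 6000 nM to 32000 nM, meaning an expected step of a 1.0-fold higher number from compound 1 to compound 4 (0.01 log units; within the scatter).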

Compound 4, half-maximal inhibitory concentration: 5510 nM
Estimate against measurement, compound 4: 2.5-fold (0.40 log units) above; the measured number lies below the stated range.
By their numbers in this assay, from the lowest: compound 4; then compounds 3, 1 and 2 (each within the scatter of the next).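

The aryl group on the sulfonyl sulfur turns out not to be indifferent in this assay: 4-methoxyphenyl in place of 3-fluorophenyl gives a 2.5-fold lower number from compound 1 to compound 4 (0.40 log units; beyond the scatter), where the exchange between the two fluorophenyl groups had stayed within the scatter. The same holds with the fluoro group of compound 2 as the starting point, since methoxy in place of fluoro on an aromatic carbon gives a 2.6-fold lower number from compound 2 to compound 4 (0.42 log units; beyond the scatter), so compound 4 stands apart from both fluorinated compounds. Nothing measured here accounts for this step.

The compounds shown leave open whether the step belongs to methoxy itself or would also come with a 3-methoxyphenyl, 4-hydroxyphenyl or 4-aminophenyl group on the sulfonyl sulfur. They also leave open whether 4-methoxyphenyl gives a similar step on the shorter chain of compound 3.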